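A few compounds are considered here, and "the series" means these few. Any claim that something is new, unique, unknown or untested is made for them only; others in the source may bear on it.

Compound 1 `COC(=O)C1(CCCCCCCCCCc2ccccc2)CO1`: 10 mg/kg
Compound 2 `CCCCCCCCCCCCCCC1(C(=O)N(C)C)CO1`: 25 mg/kg
Compound 3 `CCCCCCCCCCCCCCCCCCC1(C(=O)OC)CO1`: 10 mg/kg

In a functional assay on the whole organism with Rattus norvegicus as the target, in the glucose tolerance test (a higher number here means that more compound is needed for the effect, a lower number that less compound is needed), compound 2 gives the highest of the three numbers, standing beyond the scatter above both compound 1 and compound 3, which sit within the scatter of each other. Compound 4 `CCCCCCCCCCCCCCC1(C(=O)NCCO)CO1` differs from compound 2 in one place: (2-hydroxyethyl)amino in place of dimethylamino on a carbonyl carbon. Going by the values given here, the only measured step, no change at the digits printed from compound 1 to compound 3 (within the scatter), concerns the chain and not the amide end, so no measured pair bears on this change. With nothing to point either way, the step of no change at the digits printed from compound 2 to compound 4 (within the scatter) is expected to lie within the scatter. Compound 4 is therefore estimated at 25 mg/kg, with a range from 10 mg/kg to 60 mg/kg.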

Compound 4, minimum effective dose: 100 mg/kg
Compound 4: the middle estimate sits 4.0-fold (0.60 log units) below what was measured; measured number outside the range, above it.
By their numbers in this assay, from the lowest: compounds 1 and 3 (each within the scatter of the next); then compound 2; then compound 4.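

In this assay the amide end proves to be a position that matters: (2-hydroxyethyl)amino in place of dimethylamino on a carbonyl carbon gives a 4.0-fold higher number from compound 2 to compound 4 (0.60 log units; beyond the scatter) and so takes the dose needed further up. Going by these compounds alone, this is the first measured step at the carbonyl, as the earlier pair differed only in the chain. Nothing measured here accounts for the rise.

Still open, from the compounds shown here alone, is whether the hydroxyl or the amide hydrogen goes with this step, which methylamino or 2-methoxyethylamino on the same carbonyl would separate. Also open, going by these compounds, is how a methyl ester compares with these amides on the chain of compound 2.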